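The source may hold more compounds than are shown below. What is called first, only, known or untested is meant among the compounds shown, and "the series" means these compounds.

In a functional assay on A549 cells (Homo sapiens) for cytotoxicity, read by MTT assay, with a stated time of 72 h (a higher number here means a weaker inhibitor, a lower number a stronger inhibitor), compound 1 (`COc1ccc(/C=C2\CNC/C(=C\c3ccc(OC)c(OC)c3)C2=O)cc1OC`) gives 2900 nM. That number lies within the scatter of compound 3 (`CCN1C/C(=C\c2cc(OC)c(OC)c(OC)c2)C(=O)/C(=C/c2cc(OC)c(OC)c(OC)c2)C1`), which gives 4200 nM, while compound 2 (`COc1cc(/C=C2\CNC/C(=C\c3cc(OC)c(OC)c(OC)c3)C2=O)cc(OC)c1OC`) gives 1200 nM, lower than compound 1 by more than the scatter. Compound 4 (`COc1ccc(/C=C2\CN(C)C/C(=C\c3ccc(OC)c(OC)c3)C2=O)cc1OC`) has not yet been measured in this assay. It differs from compound 1 by a single change: methyl in place of hydrogen on an amine nitrogen in a ring. For the measured compounds named here, only one measured step bears on this change, ethyl in place of hydrogen on an amine nitrogen in a ring, which gave a 3.5-fold higher number from compound 2 to compound 3 (0.54 log units; beyond the scatter). That modest step offers limited guidance, since it was measured from compound 2 rather than compound 1 and brought in ethyl rather than methyl. Going by the values given here, a rise in the number in this assay is therefore expected, no larger than that step and possibly not clear of the scatter. The expected change is a 1.7-fold higher number from compound 1 to compound 4 (0.24 log units; within the scatter). For compound 4 the estimated value is 5000 nM, with an expected range of 2000 nM to 11000 nM.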

Compound 4, half-maximal inhibitory concentration: 1300 nM
Compound 4: the middle estimate sits 3.8-fold (0.59 log units) above what was measured; the measured number lies below the stated range.
By their numbers in this assay, from the lowest: compounds 2 and 4 (each within the scatter of the next); then compounds 1 and 3 (each within the scatter of the next).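

In this assay, methyl in place of hydrogen on an amine nitrogen in a ring gave a 2.2-fold lower number from compound 1 to compound 4 (0.35 log units; beyond the scatter), which shows that a substituent on this nitrogen can lower the number rather than raise it. For the compounds shown here, the only earlier step at this position, ethyl in place of hydrogen, gave a 3.5-fold higher number from compound 2 to compound 3 (0.54 log units; beyond the scatter), so substitution here does not shift the number in one fixed direction across these compounds. Nothing measured here accounts for the opposite directions of these two steps.

The two steps differ both in the entering group and in the rest of the molecule, so the compounds shown cannot tell which of these differences sets the direction. On these data alone, it also remains open how a longer chain, a benzyl group or an acetyl group on this nitrogen would behave.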